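Extending the amine chain of compound 3 with fluoromethyl

This account rests on a few compounds, and the source may have more. Where it says the series, first, only, none or still open, it means among the compounds named here.

Of the compounds shown here, three of one shared core have been measured. Compound 1 `CN(C)Cc1ccccc1Sc1ccc(CF)cc1N` carries a dimethylamino group on its chain and a fluoromethyl group on the second ring. In an assay on HEK293 cells for displacement of a labelled ligand from sodium-dependent dopamine transporter (Homo sapiens) (on this read-out higher numbers stand for weaker inhibition and lower numbers for stronger inhibition), compound 1 reaches only the limit of the assay, > 10000 nM, so no number is known for it, in line with the limit of > 10000 nM in this assay, at which 1 of the 3 values shown sits. Compound 2 `Cc1ccc(Sc2ccccc2CN)c(N)c1` has an unsubstituted chain amine and gives 5300 nM. Compound 3 `CCNCc1ccccc1Sc1ccc(C)cc1N` carries an ethyl on that amine and gives 2120 nM. Among the compounds with values here, the only single-change step measured is a 2.5-fold lower number from compound 2 to compound 3 (0.40 log units; beyond the scatter). Compound 3 therefore holds the lowest of the two numbers shown, with compound 2 nearest; the third value is a limit.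

Compound 4 `Cc1ccc(Sc2ccccc2CNCCCF)c(N)c1` differs from compound 3 by fluoromethyl in place of hydrogen on a saturated chain carbon, two bonds along the chain from an amine nitrogen. Within the data shown here, no measured step adds a fluoromethyl to this chain; the one step known, a 2.5-fold lower number from compound 2 to compound 3 (0.40 log units; beyond the scatter), lengthened the same chain by a smaller piece and moved the number modestly. A further lengthening of the same chain is expected to move it less, so the estimated step is a 1.4-fold lower number from compound 3 to compound 4 (0.15 log units; within the scatter), within the scatter. Compound 4 is thus expected to give about 1500 nM in this assay, with a likely range from 600 nM to 4000 nM.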

Compound 4, inhibition constant: > 10000 nM
Compound 4: no number, only a limit (the forecaster's own chance of this, stated with the estimate: 3%); at least 6.6-fold (0.82 log units) between middle value and limit.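

In this assay, fluoromethyl on this saturated chain carbon, two bonds along the chain from an amine nitrogen, gives an at least 4.7-fold higher number from compound 3 to compound 4 (0.67 log units; beyond the scatter). The earlier compounds shown here showed only a lowering when this amine gained a small group, a 2.5-fold lower number from compound 2 to compound 3 (0.40 log units; beyond the scatter), and compound 4 shows that a further lengthening of the chain can undo that gain and more. Set against the unsubstituted amine, the 3-fluoropropyl group gives an at least 1.8-fold higher number from compound 2 to compound 4 (0.27 log units; that floor lies within the scatter), so the step from the ethyl compound is the firmer of the two readings, while the step from the free amine cannot yet be told from scatter.

From the compounds shown here alone, the value of compound 4 is a limit and not a number, so how far the loss goes stays open, and this compound shares that position with one other: the limit of > 10000 nM in this assay, at which 2 of the 4 values shown sit. Also open is whether the added chain length or the fluorine accounts for the rise, a question that a plain propyl group on the same amine nitrogen, which is not among the compounds shown, would bear on directly.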